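This account rests on a few compounds, and the source may have more. Where it says the series, first, only, none or still open, it means among the compounds named here.

Working notes on the series. Three analogues of the shared core carry different aryl groups on the carbon with a double bond to nitrogen. In a functional assay on NCI-H460 cells (Homo sapiens) for cytotoxicity, read by MTT assay, with a stated time of 72 h (on this read-out lower numbers stand for stronger inhibition and higher numbers for weaker inhibition), compound 1 `CN(C)CCn1cnnc1-c1cc(Oc2ccc(NC(=O)N/N=C/c3c[nH]c4ccccc34)cc2F)ccn1` gives 1630 nM. Compound 2 `CN(C)CCn1cnnc1-c1cc(Oc2ccc(NC(=O)N/N=C/c3cccc(Cl)c3Cl)cc2F)ccn1` gives 72 nM in this assay, and the change a 23-fold lower number from compound 1 to compound 2 (1.35 log units; beyond the scatter). Compound 3 `CN(C)CCn1cnnc1-c1cc(Oc2ccc(NC(=O)N/N=C/c3cc(Br)c(O)c(Br)c3)cc2F)ccn1` gives 3760 nM in this assay and stands highest of the three numbers: the step of a 2.3-fold higher number from compound 1 to compound 3 (0.36 log units; beyond the scatter), and the step of a 52-fold higher number from compound 2 to compound 3 (1.72 log units; beyond the scatter).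

Compound 4 `CN(C)CCn1cnnc1-c1cc(Oc2ccc(NC(=O)N/N=C/c3ccc(Cl)cc3)cc2F)ccn1` is not yet measured. Its change from compound 3 is 4-chlorophenyl in place of 3,5-dibromo-4-hydroxyphenyl on a carbon with a double bond to nitrogen. For the measured compounds named here, the step bearing most on it is a 52-fold higher number from compound 2 to compound 3 (1.72 log units; beyond the scatter), which runs in the opposite direction and involves a different chlorophenyl pattern; no measured pair covers the 4-chlorophenyl group itself. A large step toward lower numbers is therefore expected, though smaller than the return to compound 2, because compound 2 72 nM carries two chlorines where compound 4 carries one. The expected step is a 19-fold lower number from compound 3 to compound 4 (1.27 log units; beyond the scatter). In this assay compound 4 is estimated at 200 nM, with a range from 60 nM to 700 nM.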

Compound 4, half-maximal inhibitory concentration: 320 nM
Compound 4: the middle estimate sits 1.6-fold (0.20 log units) below what was measured, within the range that was stated.
By their numbers in this assay, from the lowest: compound 2; then compound 4; then compound 1; then compound 3.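

At the carbon with a double bond to nitrogen, the 4-chlorophenyl group places compound 4 inside the earlier spread: the change gives a 12-fold lower number from compound 3 to compound 4 (1.07 log units; beyond the scatter) and a 5.1-fold lower number from compound 1 to compound 4 (0.71 log units; beyond the scatter) in this assay, while the other comparison gives a 4.4-fold higher number from compound 2 to compound 4 (0.65 log units; beyond the scatter). The two chlorophenyl compounds, compound 2 and compound 4, now hold the two lowest numbers of the four, so a low number at this position is not confined to the 2,3-dichlorophenyl group, although that group still gives the lower number of the pair. No measurement in hand accounts for these differences.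

Compound 2 and compound 4 differ in both the number and the placing of chlorine, so these two compounds cannot separate those two changes. From the compounds shown here alone, how an amine or a carboxylic acid in place of the chlorine of the 4-chlorophenyl group would behave remains open.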